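The source may hold more compounds than are shown below. What is called first, only, known or untested is meant among the compounds shown, and "the series" means these compounds.

Measured compounds: compound 1 `Cc1cccc(-c2noc([C@H](C)NC(=O)c3cc(C(F)(F)F)nn3C)n2)n1`, compound 2 `Cc1cncc(-c2noc([C@H](C)NC(=O)c3cc(C(F)(F)F)nn3C)n2)c1`, compound 3 `C[C@H](NC(=O)c1cc(C(F)(F)F)nn1C)c1nc(-c2cnn(C)c2)no1`.

In an assay on T-REx-293 cells for inhibition of potassium channel subfamily T member 1 (Homo sapiens), read by patch clamp (a higher number here means a weaker inhibitor, a lower number a stronger inhibitor), compound 1 gives only a limit, > 30000 nM. Compound 2 gives 1370 nM. Compound 3 gives 2640 nM, the higher of the two numbers, with compound 2 nearest at a 1.9-fold higher number from compound 2 to compound 3 (0.28 log units; within the scatter). Compound 4 `C[C@H](NC(=O)c1cc(C(F)(F)F)nn1C)c1nc(-c2ccnc(N(C)C)c2)no1` differs from compound 3 by 2-(dimethylamino)pyridin-4-yl in place of 1-methyl-1H-pyrazol-4-yl on an aromatic carbon. For the measured compounds named here, the steps that bear on this exchange are an at least 21-fold lower number from compound 1 to compound 2 (1.34 log units; beyond the scatter), an at least 11-fold lower number from compound 1 to compound 3 (1.05 log units; beyond the scatter) and a 1.9-fold higher number from compound 2 to compound 3 (0.28 log units; within the scatter): the 6-methylpyridin-2-yl of compound 1 stood far apart, whereas the 5-methylpyridin-3-yl of compound 2 and the 1-methyl-1H-pyrazol-4-yl of compound 3 lay within the scatter of each other. A further six-membered ring with one ring nitrogen is therefore expected to give a step within the scatter, a 1.7-fold lower number from compound 3 to compound 4 (0.22 log units; within the scatter). For compound 4 the estimate in this assay is 1600 nM, between 400 nM and 6500 nM.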

Compound 4, half-maximal inhibitory concentration: 454 nM
Estimate against measurement, compound 4: 3.5-fold (0.55 log units) above; measured number inside the range.
By their numbers in this assay, from the lowest: compound 4; then compounds 2 and 3 (each within the scatter of the next). At a limit, above all of these: compound 1.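

At this aromatic carbon, between two ring nitrogen atoms, 2-(dimethylamino)pyridin-4-yl separates from both 1-methyl-1H-pyrazol-4-yl and 5-methylpyridin-3-yl, giving a 5.8-fold lower number from compound 3 to compound 4 (0.76 log units; beyond the scatter) and a 3.0-fold lower number from compound 2 to compound 4 (0.48 log units; beyond the scatter) in this assay, whereas those two groups lay within the scatter of each other. The widest gap, an at least 66-fold lower number from compound 1 to compound 4 (1.82 log units; beyond the scatter), has compound 1 only as a limit: the limit of > 30000 nM in this assay, at which 1 of the 4 values shown sits. The compounds shown leave open whether the step belongs to the dimethylamino group or to the pyridin-4-yl ring, and how a morpholine or a primary amine would read in its place.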